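The source may report more compounds than this note shows. Statements on the series, on what has been measured and on what is new or still open speak of the compounds shown alone.

Compound 1 `CCCC#Cc1cc([C@@H]2O[C@H](CO)[C@@H](O)[C@H]2O)n2ncnc(N)c12`: 20 nM
Compound 2 `Nc1ncnn2c([C@@H]3O[C@H](CO)[C@@H](O)[C@H]3O)cc(C#Cc3cccs3)c12`: 50100 nM

In a functional assay on Z-138 cells (Homo sapiens) for antiproliferative activity, with a stated time of 72 h (on this read-out lower numbers stand for stronger inhibition and higher numbers for weaker inhibition), compound 2 has the higher of the two numbers at 50100 nM, far above compound 1 at 20 nM. Compound 3 `Nc1ncnn2c([C@@H]3O[C@H](CO)[C@@H](O)[C@H]3O)cc(-c3ccc(F)cc3F)c12` differs from compound 2 in one place: 2,4-difluorophenyl in place of 2-(thiophen-2-yl)ethynyl on an aromatic carbon. In words, 2,4-difluorophenyl replaces 2-(thiophen-2-yl)ethynyl on an aromatic carbon, so the triple bond is gone while an aromatic ring remains. Within the data shown here, only one measured step bears on this change: a 2500-fold higher number from compound 1 to compound 2 (3.40 log units; beyond the scatter), a large step that came with thiophen-2-yl in place of propyl on a triple-bonded carbon. Among the measured compounds shown here, no measured compound lacks the triple bond, so this guidance is weak. Compound 3 is expected to stay far from compound 1 and to sit modestly lower than compound 2. The expected change is a 2.5-fold lower number from compound 2 to compound 3 (0.40 log units; beyond the scatter). For compound 3 the estimated value is 20000 nM, with an expected range of 2000 nM to 100000 nM.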

Compound 3, half-maximal inhibitory concentration: 59100 nM
Compound 3: the middle estimate sits 3.0-fold (0.47 log units) below what was measured, within the range that was stated.
By their numbers in this assay, from the lowest: compound 1; then compounds 2 and 3 (each within the scatter of the next).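

In this assay, 2,4-difluorophenyl in place of 2-(thiophen-2-yl)ethynyl gives a 1.2-fold higher number from compound 2 to compound 3 (0.07 log units; within the scatter) and so makes no clear difference: on this aromatic carbon, a ring held on a triple bond and a ring attached directly cannot be told apart. With 2,4-difluorophenyl in place of pent-1-yn-1-yl there is a 3000-fold higher number from compound 1 to compound 3 (3.47 log units; beyond the scatter) and this large step shows that a second group carrying an aromatic ring also lies far from the value of compound 1, whether or not a triple bond is present. No measurement given here explains why these aromatic groups differ so much from the pent-1-yn-1-yl chain.

Going by these compounds, it remains open whether the triple bond matters for the low number of compound 1, which a plain pentyl chain on the same carbon could test. A longer chain such as hex-1-yn-1-yl, or a chain ending in an amine, would show how much the alkyne's end can change.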